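Carbamate Aryl Swap on a Shared Meroterpenoid-Type Core

This account rests on a few compounds, and the source may have more. Where it says the series, first, only, none or still open, it means among the compounds named here.

Measured compounds:
compound 1 `COc1ccc(OCCCOc2cc(=O)n(CCCO)c3c2CC(C/C=C(\C)CCC=C(C)C)C(C)(C)C3)cc1` gives 0%
compound 2 `COc1ccc(NC(=O)Oc2cc(=O)n(CCCO)c3c2CC(C/C=C(\C)CCC=C(C)C)C(C)(C)C3)cc1` gives 0%

Both were tested in a functional assay on PANC-1 cells (Homo sapiens) for inhibition, read by MTT assay, with a stated time of 24 h, tested at 10 uM; a lower number here means less inhibition, a higher number more inhibition at the concentration tested (going by the name of the read-out). Compound 2 stands level with compound 1 at the digits reported; the step of no change at the digits printed from compound 1 to compound 2 (within the scatter) changed nothing within the scatter, although it exchanged the entire group on the ring oxygen of the shared core.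

Compound 3 `CC(C)=CCC/C(C)=C/CC1Cc2c(OC(=O)Nc3ccc(F)c(F)c3)cc(=O)n(CCCO)c2CC1(C)C` is the next variation: 3,4-difluorophenyl in place of 4-methoxyphenyl on an amide-type nitrogen. Going by the values given here, the only measured step bearing on it is the one from compound 1 to compound 2, which replaced the whole substituent on that oxygen and left the read-out flat. Among the compounds with values here, no measured step alters the aryl on the amide-type nitrogen itself, so the data give no direction for this change. The step of a number 3 percentage points higher from compound 2 to compound 3 (within the scatter) is therefore expected to be none beyond the scatter. Compound 3 is estimated at 3%, with a range from 0% to 20%.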

Compound 3, a percentage reported as inhibition, at one concentration (the size of the read-out at that concentration, not a potency): 4.8%
For compound 3 the middle estimate is 1.8 percentage points below the measured one; the measured number falls inside the stated range.
By their numbers in this assay, from the lowest: compounds 1, 2 and 3 (each within the scatter of the next).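

In this assay, going by these compounds alone, the 3,4-difluorophenyl in place of 4-methoxyphenyl on an amide-type nitrogen is the first change to the aryl itself, and it moves the read-out only within the scatter (a number 4.8 percentage points higher from compound 2 to compound 3 (within the scatter)). The larger exchange on the oxygen on an aromatic ring, (3,4-difluorophenyl)carbamoyl in place of 3-(4-methoxyphenoxy)propyl, also stays within the scatter (a number 4.8 percentage points higher from compound 1 to compound 3 (within the scatter)), so none of the three compounds separates from the others at the concentration tested. No supporting measurement is available to explain this flat result.

Going by these compounds, whether an amine or a carboxylic acid on this aryl, or a longer chain in place of the aryl, would give a clear read-out remains open. On these data alone, the effect of any change to the shared core also remains open.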